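Trimming One Methoxy Group on the Carbonyl-Side Ring

The source may hold more compounds than are shown below. What is called first, only, known or untested is meant among the compounds shown, and "the series" means these compounds.

Two measured compounds set the scene. In a functional assay on SN12C cells (Homo sapiens) for cytotoxicity, read by sulforhodamine B assay, with a stated time of 48 h, tested at 0.1 uM (on this read-out lower numbers stand for a stronger effect and higher numbers for a weaker effect at the one concentration tested), compound 2 `COc1ccc(C(=O)/C=C/c2cc(-c3cc(OC)c(OC)c(OC)c3)n[nH]2)cc1OC` gives 94%, and in this assay compound 1 `COc1cc(-c2cc(/C=C/C(=O)c3ccc(N)cc3)[nH]n2)cc(OC)c1OC` gives 99%. Of the two numbers, compound 2 stands lowest, but the nearest number, that of compound 1, lies within the usual scatter, so neither compound can be called the stronger. Within the data shown here, the single measured step, a number 5 percentage points lower from compound 1 to compound 2 (within the scatter), swapped the whole ring attached to the carbonyl carbon and still moved the read-out by less than the scatter.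

Compound 3 `COc1ccc(C(=O)/C=C/c2cc(-c3cc(OC)c(OC)c(OC)c3)n[nH]2)cc1` is not yet measured. It differs from compound 2 in one place: hydrogen in place of methoxy on an aromatic carbon. This is a smaller change on the same ring that the measured step exchanged entirely, and that exchange gave no step beyond the scatter. On that basis the step from compound 2 to compound 3 is expected to be small, a number 1 percentage points higher from compound 2 to compound 3 (within the scatter), with no clear direction. Compound 3 is therefore estimated at 95% in this assay, within a range from 82% to 106%.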

Compound 3, a percentage reported as activity, at one concentration (the size of the read-out at that concentration, not a potency): 96%
For compound 3 the middle estimate is 1 percentage points below the measured one; the range from low to high includes it.
By their numbers in this assay, from the lowest: compounds 2, 3 and 1 (each within the scatter of the next).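

In this assay, the swap of 3,4-dimethoxyphenyl to 4-methoxyphenyl gives a number 2 percentage points higher from compound 2 to compound 3 (within the scatter) and so does not separate methoxy from hydrogen at this position, ortho to a methoxy group and meta to a large group. Compound 3 also forms a second one-place pair, since methoxy in place of amino on an aromatic carbon gives a number 3 percentage points lower from compound 1 to compound 3 (within the scatter), which means that this swap, like the loss of a single methoxy group, produces no difference that can be read at the one concentration tested. Nothing measured here bears on why these compounds sit so close together in this read-out.

What the compounds shown leave open is whether any group on this ring can move the number beyond the usual scatter, for example a hydroxyl, a fluorine, a carboxylic acid or a longer chain such as butoxy in place of the methoxy group. Going by these compounds, with only one low concentration to go on, it also remains open whether the hydrogen and methoxy compounds would still match at higher concentrations.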